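Compound 3 to compound 4: adding a hydroxy

This account rests on a few compounds, and the source may have more. Where it says the series, first, only, none or still open, it means among the compounds named here.

In a functional assay on HCT-8 cells (Homo sapiens) for antiproliferative activity, read by sulforhodamine B assay, with a stated time of 48 h (a higher number here means a weaker inhibitor, a lower number a stronger inhibitor), compound 3 `COc1ccc(/C=C/C(=O)c2ccccc2-c2cccc(F)c2)cc1` gives 200 nM. Compound 1 `COc1ccc(/C=C/C(=O)c2ccccc2-c2ccc(F)cc2)cc1` gives 220 nM, and the exchange of 4-fluorophenyl for 3-fluorophenyl, a 1.1-fold lower number from compound 1 to compound 3 (0.04 log units; within the scatter), stays within the scatter, so these two compounds cannot be told apart. Compound 2 `COc1ccc(/C=C/C(=O)c2ccccc2-c2ccc(F)cc2)cc1O` gives 38 nM, the lowest number of the three.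

Compound 4 `COc1ccc(/C=C/C(=O)c2ccccc2-c2cccc(F)c2)cc1O` differs from compound 3 by hydroxy in place of hydrogen on an aromatic carbon, ortho to a methoxy group and meta to a large group. Among the compounds with values here, the only measured step of this kind is a 5.8-fold lower number from compound 1 to compound 2 (0.76 log units; beyond the scatter), which is modest but beyond the scatter. It made the same change at the same place, though it rests on a single pair. With the fluorine exchange showing no measurable difference, a similar drop is expected here, an estimated 5.7-fold lower number from compound 3 to compound 4 (0.76 log units; beyond the scatter). For compound 4 the expected value is 35 nM, with an estimated range of 15 nM to 90 nM.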

Compound 4, half-maximal inhibitory concentration: 16 nM
Estimate against measurement, compound 4: 2.2-fold (0.34 log units) above, and the stated range covers the measured number.
By their numbers in this assay, from the lowest: compound 4; then compound 2; then compounds 3 and 1 (each within the scatter of the next).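

In this assay, hydroxy in place of hydrogen, ortho to a methoxy group, now also lowers the number with the 3-fluorophenyl group, a 13-fold lower number from compound 3 to compound 4 (1.10 log units; beyond the scatter), so the effect no longer rests on a single pair, and the two readings agree: the same change on two cores in this assay, a 5.8-fold lower number (0.76 log units; beyond the scatter) from compound 1 to compound 2 and a 13-fold lower number (1.10 log units; beyond the scatter) from compound 3 to compound 4, 2.2-fold (0.33 log units) apart, within the scatter of two such steps. The fluorine exchange, which could not be told apart without the hydroxy, now gives a 2.4-fold lower number from compound 2 to compound 4 (0.38 log units; beyond the scatter), a step beyond the scatter. Even so, this step does not clearly differ from the earlier one, so no firm preference between the two fluorophenyl groups follows: the same change on two cores in this assay, a 1.1-fold lower number (0.04 log units; within the scatter) from compound 1 to compound 3 and a 2.4-fold lower number (0.38 log units; beyond the scatter) from compound 2 to compound 4, 2.2-fold (0.33 log units) apart, within the scatter of two such steps.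

From the compounds shown here alone, whether an amine or a second methoxy group on this aromatic carbon would lower the number as hydroxy does remains open. Also open, going by these compounds, is what a chlorine in place of the fluorine would do, with or without the hydroxy.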